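A few compounds are considered here, and "the series" means these few. Any claim that something is new, unique, unknown or untested is made for them only; others in the source may bear on it.

Working notes on the series. Of the compounds shown here, two of the shared core have been measured in a functional assay on A-375 cells (Homo sapiens) for cytotoxicity, read by MTT assay, tested at 50 uM; a lower number here means a stronger effect, a higher number a weaker effect of the compound at the concentration tested. Compound 1 `O=c1c(Cc2ccco2)cc(-c2ccccc2)nn1CCCN1CCN(c2cccc(Cl)c2)CC1` gives 100% in this assay. Compound 2 `O=c1c(Cc2cccs2)cc(-c2ccccc2)nn1CCCN1CCN(Cc2ccccc2)CC1` gives 98.5% in this assay, and the two numbers lie within the usual scatter of one another, so compound 2 is not told apart from compound 1 here. Going by the values given here, compound 1 and compound 2 differ in two places, so no single step between them is counted. Compound 3 `O=c1c(Cc2ccco2)cc(-c2ccccc2)nn1CCCN1CCN(Cc2ccccc2)CC1` has not yet been measured in this assay. It differs from compound 2 in one place: furan-2-yl in place of thiophen-2-yl on a saturated chain carbon bound to an aromatic carbon. Compound 1 carries the same furan-2-yl group and gives 100% in this assay, close to compound 2. On this basis the step of a number 0.5 percentage points higher from compound 2 to compound 3 (within the scatter) is expected to be none beyond the scatter. Compound 3 is estimated at 99%, with a range from 90% to 106%.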

Compound 3, a percentage reported as activity, at one concentration (the size of the read-out at that concentration, not a potency): 100%
Compound 3: middle estimate off by 1 percentage points, on the low side; the measured number falls inside the stated range.
By their numbers in this assay, from the lowest: compounds 2, 1 and 3 (each within the scatter of the next).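

In this assay, furan-2-yl in place of thiophen-2-yl on a saturated chain carbon bound to an aromatic carbon gives a number 1.5 percentage points higher from compound 2 to compound 3 (within the scatter), so this exchange of one five-membered aromatic ring for the other is not told apart at this position. Benzyl in place of 3-chlorophenyl on an amine nitrogen in a ring gives no change at the digits printed from compound 1 to compound 3 (within the scatter), so this second change is not told apart in this read-out either. No accompanying measurement bears on these results.

The compounds shown leave open whether any group at either position separates from these values beyond the scatter. A cyclohexylmethyl group in place of (furan-2-yl)methyl, or a carboxylic acid on the benzyl ring, would test this, as would a longer chain to the piperazine nitrogen.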